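The compounds below may be only part of what the source reports. "The series", "measured", "known", "first", "only" and "open" are said of these compounds alone.

Working notes on the series. Of the compounds shown here, three have been measured in a functional assay on M14 cells (Homo sapiens) for cytotoxicity, read by sulforhodamine B assay, with a stated time of 48 h; a higher number here means a weaker inhibitor of growth, a lower number a stronger inhibitor of growth. Compound 1 `ClCc1cccc(Cn2cnc3ncnc(Cl)c32)c1` gives 14500 nM. Compound 2 `ClCc1ccccc1Cn1cnc2ncnc(Cl)c21` gives 5120 nM in this assay. Compound 3 `ClCc1cccc(Cn2cnc3nc(Cl)nc(Cl)c32)c1` gives 2630 nM in this assay. Compound 1 and compound 2 carry the same atoms joined differently; the difference between the two cores is not broken down here. Compound 2 and compound 3 stand within the scatter of each other, while compound 1 lies beyond the scatter from both.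

Within the data shown here, the one change followed across measured compounds is chloro in place of hydrogen on an aromatic carbon, which gave a 5.5-fold lower number from compound 1 to compound 3 (0.74 log units; beyond the scatter). The unmeasured compound 4 `ClCc1ccccc1Cn1cnc2nc(Cl)nc(Cl)c21` is made from compound 2 by chloro in place of hydrogen on an aromatic carbon. The place of the entering chloro is described in the same words in both cases, so this is the same change carried over to the core of compound 2. Among the measured compounds shown here, only one prior instance of the change is known, and the two cores differ, so the expected step is set slightly short of the earlier one.

Compound 4 is expected near 1100 nM in this assay, with a likely range from 400 nM to 3000 nM. The step expected is a 4.7-fold lower number from compound 2 to compound 4 (0.67 log units; beyond the scatter), and it rests on the measured step of a 5.5-fold lower number from compound 1 to compound 3 (0.74 log units; beyond the scatter) applied to the value of compound 2.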

Compound 4, concentration for total growth inhibition: 3460 nM
Beside the measured number, compound 4's estimate is 3.1-fold (0.50 log units) below it, and the stated range ends below it.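

With chloro in place of hydrogen on an aromatic carbon, the core of compound 2 gives a 1.5-fold lower number from compound 2 to compound 4 (0.17 log units; within the scatter), a step that cannot be told apart from repeat scatter. Among these compounds, the change therefore does not carry over at its earlier size, and the two steps differ by more than their scatter allows, so the size of the step depends on the core that receives the chloro: the same change on two cores in this assay, a 5.5-fold lower number (0.74 log units; beyond the scatter) from compound 1 to compound 3 and a 1.5-fold lower number (0.17 log units; within the scatter) from compound 2 to compound 4, 3.7-fold (0.57 log units) apart, beyond the scatter of two such steps This does not show why the two cores differ, and with only two pairs it gives no rule for a third core; nor does it show that the direction is shared, since the step on the core of compound 2 lies within the scatter.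

Still open, as far as these compounds go, is whether an amine or a methoxy group, placed on the same aromatic carbon between two ring nitrogen atoms, would separate the two cores in the same way as chloro or would behave alike on both. Also open, from the compounds shown here alone, is whether the gap between the two steps persists when the chloromethyl group is replaced by a hydroxymethyl group or a longer chain, and whether it appears in cell lines other than the one in this assay.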